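Series notes: aryl change on the amide-type nitrogen

A few compounds are considered here, and "the series" means these few. Any claim that something is new, unique, unknown or untested is made for them only; others in the source may bear on it.

Measured so far in an assay on CHO cells for antagonist activity at transient receptor potential cation channel subfamily V member 1 (Homo sapiens), read by scintillation counting, with a stated time of 5 min, in the presence of a further agent that is not named here; a higher number here means that more compound is needed for the effect, a lower number that less compound is needed:
compound 1 `CC(C(=O)NCc1ccc(C(F)(F)F)cc1N1CCC(Cc2ccccc2)(N(C)C)CC1)c1ccc(NS(C)(=O)=O)c(F)c1`: 8.2 nM
compound 2 `CN(C)C1(Cc2ccccc2)CCN(c2cc(C(F)(F)F)ccc2CNC(=O)Nc2ccc3c(c2)OCC3)CC1`: 31.3 nM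

Compound 2 stands highest of the two numbers in this assay; compound 1 gives a lower number, and that gap lies beyond the usual scatter. Compound 3 `CN(C)C1(Cc2ccccc2)CCN(c2cc(C(F)(F)F)ccc2CNC(=O)Nc2cccc3cnccc23)CC1` differs from compound 2 by a group of 10 heavy atoms (9 carbon, 1 nitrogen; one six-membered aromatic ring of carbon only, one six-membered aromatic ring with 1 hetero atom) in place of a group of 9 heavy atoms (8 carbon, 1 oxygen; one five-membered non-aromatic ring with 1 hetero atom, one six-membered aromatic ring of carbon only), on an amide-type nitrogen. Going by the values given here, no measured pair shows a change of this kind, so nothing here fixes its size; the expectation is a step of a 1.0-fold lower number from compound 2 to compound 3 (0.02 log units; within the scatter), within the scatter. For compound 3 the estimated value in this assay is 30 nM, with a range from 10 nM to 100 nM.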

Compound 3, half-maximal effective concentration: 8.8 nM
Estimate against measurement, compound 3: 3.4-fold (0.53 log units) above; measured number outside the range, below it.
By their numbers in this assay, from the lowest: compounds 1 and 3 (each within the scatter of the next); then compound 2.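

Isoquinolin-5-yl on the amide-type nitrogen, in place of the group carried by compound 2, gives a 3.6-fold lower number from compound 2 to compound 3 (0.55 log units; beyond the scatter) in this assay, so this position responds to a change of group. The two groups have equal counts of hydrogen-bond donors and acceptors, so those counts do not separate them. Nothing measured here accounts for the step. The compounds shown leave open whether the ring nitrogen of isoquinolin-5-yl matters. A naphthalen-1-yl group on the same nitrogen, all carbon in its rings, would test this.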